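Rat microsomal stability: piperidine in place of ethylpiperazine

A few compounds are considered here, and "the series" means these few. Any claim that something is new, unique, unknown or untested is made for them only; others in the source may bear on it.

Compound 3 `CCN1CCN(CCCN(C[C@H]2Cc3ccccc3CN2)[C@H]2CCCc3cccnc32)CC1` stands lowest of the three compounds measured in an ADME assay on microsomes from liver (Rattus norvegicus) for metabolic stability, read by LC-MS, with a stated time of 10 min, tested at 0.5 uM; a lower number here means that less of the compound is left, a higher number that more of the compound is left: compound 3 gives 1%. Its nearest neighbour is compound 2 `CC(C)N1CCN(CCCN(C[C@H]2Cc3ccccc3CN2)[C@H]2CCCc3cccnc32)CC1`, which in this assay gives 4%; the gap between them, a number 3 percentage points lower from compound 2 to compound 3 (within the scatter), is within the scatter. Furthest away is compound 1 `c1ccc2c(c1)CN[C@@H](CN(CC[C@H]1CCCNC1)[C@H]1CCCc3cccnc31)C2`, which in this assay gives 55%.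

Compound 4 `c1ccc2c(c1)CN[C@@H](CN(CCC1CCNCC1)[C@H]1CCCc3cccnc31)C2` has not been measured yet. It differs from compound 3 in one place: piperidin-4-yl in place of (4-ethylpiperazin-1-yl)methyl on a saturated chain carbon, two bonds along the chain from an amine nitrogen.

Going by the values given here, two measured steps bear on this. From compound 1 to compound 3 the piperidin-3-yl group was replaced by (4-ethylpiperazin-1-yl)methyl, and this assay fell by a number 54 percentage points lower from compound 1 to compound 3 (beyond the scatter); the parallel replacement with (4-isopropylpiperazin-1-yl)methyl gave a number 51 percentage points lower from compound 1 to compound 2 (beyond the scatter). The change to compound 4 reverses the first of these, with piperidin-4-yl in place of piperidin-3-yl. A large rise in this assay is therefore expected, of the order of a number 44 percentage points higher from compound 3 to compound 4 (beyond the scatter), though the shift in ring attachment adds uncertainty. Compound 4 is expected to give about 45% in this assay, within a range from 20% to 70%.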

Compound 4, percent of the compound remaining: 17%
For compound 4 the middle estimate is 28 percentage points above the measured one; the measured number lies below the stated range.
By their numbers in this assay, from the lowest: compounds 3 and 2 (each within the scatter of the next); then compound 4; then compound 1.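

In this assay, the saturated chain carbon, two bonds along the chain from an amine nitrogen, responds to the attachment point of the piperidine ring and not only to the loss of the piperazine: piperidin-4-yl in place of piperidin-3-yl gives a number 38 percentage points lower from compound 1 to compound 4 (beyond the scatter). Replacing either piperazine group with piperidin-4-yl recovers only part of the gap, with a number 16 percentage points higher from compound 3 to compound 4 (beyond the scatter) and a number 13 percentage points higher from compound 2 to compound 4 (beyond the scatter). Among these four compounds, a piperidine alone does not carry the high number; only the piperidin-3-yl of compound 1 does.

No data here explain why the attachment point has so large an effect. Still open, on these data alone, is how piperidin-2-yl, or a methyl on the nitrogen of piperidin-3-yl, would read in this assay.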